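Cyclopropylamino to dimethylamino: working notes

This account rests on a few compounds, and the source may have more. Where it says the series, first, only, none or still open, it means among the compounds named here.

In an ADME assay on HEp-2 cells (Homo sapiens) for cytotoxicity (on this read-out lower numbers stand for higher toxicity in this test and higher numbers for lower toxicity in this test), compound 1 `CNCc1ccc2c(c1)nc(Cn1c(=O)n(C(C)C)c3ccccc31)n2CCC(C)C` gives 1480 nM and compound 2 `CC(C)CCn1c(Cn2c(=O)n(C(C)C)c3ccccc32)nc2cc(CNC3CC3)ccc21` gives 17200 nM, so compound 2 holds the higher of the two numbers. Going by the values given here, only one measured step bears on the next change: a 12-fold higher number from compound 1 to compound 2 (1.07 log units; beyond the scatter). That step is large and beyond the scatter, and it places cyclopropyl in place of methyl on an amine nitrogen.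

Compound 3 `CC(C)CCn1c(Cn2c(=O)n(C(C)C)c3ccccc32)nc2cc(CN(C)C)ccc21` is still unmeasured. Its difference from compound 2 is dimethylamino in place of cyclopropylamino on a saturated chain carbon bound to an aromatic carbon. Among the compounds with values here, compound 3 loses the cyclopropyl and has methyl on the amine nitrogen, as compound 1 does, but it carries a second methyl, and no measured step covers that addition. Within the data shown here, with a 12-fold higher number from compound 1 to compound 2 (1.07 log units; beyond the scatter) as the only guide, a move back towards compound 1 is expected, to a lower number in this assay, though probably not the whole way. The expected step is a 4.3-fold lower number from compound 2 to compound 3 (0.63 log units; beyond the scatter). For compound 3 the estimate is 4000 nM, with an expected range of 1200 nM to 13000 nM.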

Compound 3, half-maximal cytotoxic concentration: 5650 nM
The estimate for compound 3 lay 1.4-fold (0.15 log units) below the measured number; the range from low to high includes it.
By their numbers in this assay, from the lowest: compound 1; then compound 3; then compound 2.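

Cyclopropylamino to dimethylamino: what the result adds

In this assay the group on the saturated chain carbon bound to an aromatic carbon still moves the number when no cyclopropyl is present: the step of a 3.8-fold higher number from compound 1 to compound 3 (0.58 log units; beyond the scatter) comes from methyl in place of hydrogen on the amine nitrogen alone. Removing the three-membered ring therefore does not return the series to the level of compound 1, and a 3.0-fold lower number from compound 2 to compound 3 (0.48 log units; beyond the scatter) shows that dimethylamino nonetheless remains clearly separated from cyclopropylamino on this read-out. Across these three compounds, both replacements of the methylamino group of compound 1 give higher numbers, with cyclopropylamino the higher of the two, so the amine nitrogen is a sensitive place in this series. Nothing measured here explains these differences.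

From the compounds shown here alone, whether the number follows the group on the nitrogen in any regular way stays open, since ethylamino, isopropylamino, cyclobutylamino or a primary amine could separate the effect of the ring from that of the carbon count. A pyrrolidine ring at the same place would also test whether a ring that takes in the nitrogen behaves like dimethylamino or like cyclopropylamino.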